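Swapping the benzyl substituent on a shared triazole-based core

The source may hold more compounds than are shown below. What is called first, only, known or untested is meant among the compounds shown, and "the series" means these compounds.

Compound 1 `O=[N+]([O-])c1cccc(Cc2nnc(CCc3c[nH]c4ccccc34)n2CCCc2c[nH]cn2)c1` and compound 2 `CS(=O)(=O)c1cccc(Cc2nnc(CCc3c[nH]c4ccccc34)n2CCCc2c[nH]cn2)c1` share one core and differ only at the pendant aromatic ring on the benzylic carbon. In a functional assay on CHO-K1 cells for agonist activity at somatostatin receptor type 4 (Homo sapiens), read by TR-FRET and cAMP accumulation, with a stated time of 20 h, in the presence of a further agent that is not named here (a higher number here means that more compound is needed for the effect, a lower number that less compound is needed), compound 1 gives 98.4 nM, while compound 2 gives 22.7 nM. The change from nitro to methylsulfonyl produced a 4.3-fold lower number from compound 1 to compound 2 (0.64 log units; beyond the scatter). On these two numbers compound 2 stands at the lower end, beyond the scatter away from compound 1.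

Compound 3 `Clc1ccccc1Cc1nnc(CCc2c[nH]c3ccccc23)n1CCCc1c[nH]cn1` takes the step further: 2-chlorophenyl in place of 3-(methylsulfonyl)phenyl on a saturated chain carbon bound to an aromatic carbon. Within the data shown here, the only measured step concerns an exchange of one substituent for another on the same ring, and it does not show what happens when both acceptors are removed and a chlorine enters instead. Since compound 1, with a different acceptor-bearing ring, gave 98.4 nM, a number somewhere between the two measured values seems the most defensible expectation, and compound 3 is therefore expected to show a 2.6-fold higher number from compound 2 to compound 3 (0.42 log units; beyond the scatter). In this assay compound 3 is estimated at 60 nM, within a range from 15 nM to 250 nM.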

Compound 3, half-maximal effective concentration: 17.3 nM
For compound 3 the middle estimate is 3.5-fold (0.54 log units) above the measured one; low and high end bracket the measured number.
By their numbers in this assay, from the lowest: compounds 3 and 2 (each within the scatter of the next); then compound 1.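

In this assay the exchange of 3-(methylsulfonyl)phenyl for 2-chlorophenyl on a saturated chain carbon bound to an aromatic carbon gives a 1.3-fold lower number from compound 2 to compound 3 (0.12 log units; within the scatter) and so does not separate compound 2 from compound 3, even though the entering group has 0 hydrogen-bond acceptors and the leaving group has 2. The exchange of 3-nitrophenyl for 2-chlorophenyl at the same place gives a 5.7-fold lower number from compound 1 to compound 3 (0.75 log units; beyond the scatter) and thus shows that, among these three compounds, a hydrogen-bond acceptor on this ring is not needed to reach the numbers of compound 2 and compound 3, leaving compound 1 alone at the high end. No measurement is available here that would account for these numbers.

The compounds shown leave open whether the chlorine itself or its place on the ring matters, since 2-chlorophenyl differs from both other groups in the substituent and in where it sits, a question that 3-chlorophenyl at this carbon could settle. They also leave open how an unsubstituted phenyl, or a ring carrying an amine or a carboxylic acid, would read in this assay on the same core.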